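Naphthalenesulfonamide series: chloro replacing isopropylamino

The compounds below may be only part of what the source reports. "The series", "measured", "known", "first", "only" and "open" are said of these compounds alone.

Measured so far in an assay on VSM-A10 cells for antagonist activity at Endothelin-1 receptor (Rattus norvegicus); on this read-out lower numbers stand for stronger inhibition and higher numbers for weaker inhibition:
compound 1 `Cc1noc(NS(=O)(=O)c2cccc3c(NC(C)C)cccc23)c1C`: 20 nM
compound 2 `CCc1noc(NS(=O)(=O)c2cccc3c(N(C)C)cccc23)c1C`: 1170 nM
compound 3 `Cc1noc(NC(=O)c2ccc(N)cc2)c1C`: a limit of the assay, > 32000 nM

Compound 1 holds the lowest of the two numbers given; compound 2 sits far higher, well beyond the scatter. Compound 3 reaches only the limit, (the limit of > 32000 nM in this assay, at which 1 of the 3 values shown sits).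

Compound 4 `Cc1noc(NS(=O)(=O)c2cccc3c(Cl)cccc23)c1C` is not yet measured. It differs from compound 1 by chloro in place of isopropylamino on an aromatic carbon. Going by the values given here, no measured pair isolates this change; the comparison of compound 1 with compound 2 spans two alterations at once. A loss in this assay is expected, of moderate size: the estimated step of a 13-fold higher number from compound 1 to compound 4 (1.10 log units; beyond the scatter). For compound 4 the expected value is 250 nM, in a range from 50 nM to 1500 nM.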

Compound 4, half-maximal inhibitory concentration: 24000 nM
The estimate for compound 4 lay 96-fold (1.98 log units) below the measured number; the whole stated range lies below it.
By their numbers in this assay, from the lowest: compound 1; then compound 2; then compound 4. At a limit, above all of these: compound 3.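

In this assay, exchanging isopropylamino for chloro on this aromatic carbon, with the rest of the core of compound 1 unchanged, gives a 1200-fold higher number from compound 1 to compound 4 (3.08 log units; beyond the scatter). Going by these compounds alone, this is the first comparison that isolates a single place, and it shows that inhibition depends heavily on the group here and that chloro does not stand in for isopropylamino. Little room remains in the read-out above compound 4, and compound 3 stands at a limit: the limit of > 32000 nM in this assay, at which 1 of the 4 values shown sits.

Still open, on these data alone, is how a primary amine, a methoxy group or a longer alkylamino chain would read out at this place. The compounds shown therefore do not separate the part played by the nitrogen of isopropylamino from that of its carbons.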